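A few compounds are considered here, and "the series" means these few. Any claim that something is new, unique, unknown or untested is made for them only; others in the source may bear on it.

In a functional assay on 4T1 cells (Mus musculus) for cytotoxicity, read by MTT assay, with a stated time of 24 h (on this read-out higher numbers stand for weaker inhibition and lower numbers for stronger inhibition), compound 1, `O=C1/C(=C/c2ccccc2F)CN(C(=S)SCc2cn(Cc3ccccc3Cl)nn2)C/C1=C\c1ccccc1F`, gives 43600 nM, while compound 2, `O=C1/C(=C/c2ccccc2F)CN(C(=S)SCc2cn(Cc3ccccc3F)nn2)C/C1=C\c1ccccc1F`, gives 30700 nM. These two share a core and differ in one place only: chloro in place of fluoro on an aromatic carbon. That single change produced a 1.4-fold higher number from compound 2 to compound 1 (0.15 log units; within the scatter), so the two values cannot be told apart with confidence.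

Compound 3, `Cc1ccc(/C=C2\CN(Cc3cn(Cc4ccccc4F)nn3)C/C(=C\c3ccc(C)cc3)C2=O)cc1`, is built on a different core; how its core differs from that of compound 2 is not broken down here. In this assay compound 3 gives 18000 nM.

Compound 4, `Cc1ccc(/C=C2\CN(Cc3cn(Cc4ccccc4Cl)nn3)C/C(=C\c3ccc(C)cc3)C2=O)cc1`, has not yet been measured. It differs from compound 3 in the same way that compound 1 differs from compound 2: chloro in place of fluoro on an aromatic carbon. Because the earlier occurrence of this change gave a 1.4-fold higher number from compound 2 to compound 1 (0.15 log units; within the scatter), the expectation is a step of about the same modest size, which is a 1.4-fold higher number from compound 3 to compound 4 (0.14 log units; within the scatter). On that basis compound 4 is estimated to give 25000 nM in this assay, most likely somewhere between 12000 nM and 50000 nM.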

Compound 4, half-maximal inhibitory concentration: 23200 nM
Estimate against measurement, compound 4: 1.1-fold (0.03 log units) above; the measured number falls inside the stated range.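

In this assay, replacing 2-fluorobenzyl with 2-chlorobenzyl on the second core gives a 1.3-fold higher number from compound 3 to compound 4 (0.11 log units; within the scatter), so once again the two values cannot be told apart. Set side by side, the two steps agree, and on these two cores the change behaves in the same way: the same change on two cores in this assay, a 1.4-fold higher number (0.15 log units; within the scatter) from compound 2 to compound 1 and a 1.3-fold higher number (0.11 log units; within the scatter) from compound 3 to compound 4, 1.1-fold (0.04 log units) apart, within the scatter of two such steps

This shows that, for these two pairs, the small step seen on one core was also seen on the other, but it does not show that the change has a real effect on either core, since each step on its own is lost in the scatter, nor does it establish a rule for cores beyond these two.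

The compounds shown leave open what a clearly different group in the same place would do, such as a methoxy group, an amine or a carboxylic acid instead of fluoro or chloro. Also open, as far as these compounds go, is whether this swap would stay as small on a third core or in another cell line.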